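A few compounds are considered here, and "the series" means these few. Any claim that something is new, unique, unknown or untested is made for them only; others in the source may bear on it.

Measured in an ADME assay on MRC5 cells (Homo sapiens) for cytotoxicity, read by fluorescence, with a stated time of 24 h; on this read-out lower numbers stand for stronger inhibition and higher numbers for weaker inhibition:

- compound 1 `C=CCN1C(=O)C(CC(=O)c2ccc(F)cc2)S/C1=N\N=C\c1ccccc1`: 20100 nM
- compound 2 `O=C(CC1S/C(=N\N=C\c2c(-c3ccccc3)[nH]c3ccccc23)NC1=O)c1ccccc1`: > 50000 nM
- compound 3 `CC1S/C(=N\N=C\c2c(-c3ccc(Br)cc3)[nH]c3ccccc23)NC1=O`: > 50000 nM

Compound 2 gives > 50000 nM, which is a limit and not a number. It shares this position with one other compound, as the limit of > 50000 nM in this assay, at which 2 of the 3 values shown sit, records. Compound 1 is the only one of the three that gives a number, 20100 nM.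

The next compound is compound 4 `CCC1S/C(=N\N=C\c2c(-c3ccccc3)[nH]c3ccccc23)NC1=O`, not yet measured in this assay. It differs from compound 2 as follows: methyl in place of benzoyl on a saturated chain carbon bound to a saturated ring carbon.

Compound 3 also lacks the benzoyl and gives > 50000 nM, again a limit. Among the compounds with values here, no measured pair isolates this change, so no step beyond the scatter is expected, and no direction can be given. The expected change is a step that the limit leaves unreadable from compound 2 to compound 4. The estimate for compound 4 is 55000 nM, with an expected range from 22000 nM to 120000 nM.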

Compound 4, half-maximal inhibitory concentration: > 50000 nM
Compound 4 gave a limit, no number; the forecaster's own chance of this, stated with the estimate: 70%; the middle value lies beyond the limit too.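

Compound 2 and compound 4 both give a limit and not a number, so no step between them can be read in this assay: the limit of > 50000 nM in this assay, at which 3 of the 4 values shown sit.

The compounds shown leave open whether methyl in place of benzoyl changes the read-out at all, and in which direction.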